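This account rests on a few compounds, and the source may have more. Where it says the series, first, only, none or still open, it means among the compounds named here.

Three compounds of the series share one core and differ in the amine group on the chain. In a functional assay (aorta) with Rattus norvegicus as the target (a lower number here means a stronger inhibitor, a higher number a weaker inhibitor), compound 1 `CC(C)c1cn2ccccc2c1S(=O)(=O)c1ccc(OCCCN2CCC(c3ccccc3)CC2)cc1` gives 80.9 nM, compound 2 `COc1ccc(CNCCCOc2ccc(S(=O)(=O)c3c(C(C)C)cn4ccccc34)cc2)cc1OC` gives 13 nM and compound 3 `COc1ccc(NCCCOc2ccc(S(=O)(=O)c3c(C(C)C)cn4ccccc34)cc2)cc1OC` gives 396 nM. Compound 3 therefore has the highest number of the three, as shown by a 4.9-fold higher number from compound 1 to compound 3 (0.69 log units; beyond the scatter) and by a 30-fold higher number from compound 2 to compound 3 (1.48 log units; beyond the scatter), the latter a large step.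

Next in the series is compound 4 `CCCN(CCC)CCCOc1ccc(S(=O)(=O)c2c(C(C)C)cn3ccccc23)cc1`, with this change: dipropylamino in place of (3,4-dimethoxyphenyl)amino on a saturated chain carbon, three bonds along the chain from an oxygen on an aromatic ring. Dipropylamino replaces (3,4-dimethoxyphenyl)amino, so the entering group has no ring.

Among the compounds with values here, no measured step brings in dipropylamino, so the evidence is indirect. Compound 3 alone carries 3,4-dimethoxyphenyl on the amine nitrogen, and the two compounds without that group both lie lower. These two also differ from each other, by a 6.2-fold lower number from compound 1 to compound 2 (0.79 log units; beyond the scatter), a modest step, so the identity of the amine matters and the size of the gain stays uncertain. A drop of modest size in this assay is expected, with the number landing near that of compound 1 at 80.9 nM. The expected change is a 5.7-fold lower number from compound 3 to compound 4 (0.75 log units; beyond the scatter). The estimate for compound 4 is 70 nM, with an expected range of 15 nM to 300 nM.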

Compound 4, half-maximal inhibitory concentration: 102 nM
Compound 4: middle estimate off by 1.5-fold (0.16 log units), on the low side; the measured number falls inside the stated range.
By their numbers in this assay, from the lowest: compound 2; then compounds 1 and 4 (each within the scatter of the next); then compound 3.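

In this assay, dipropylamino on the saturated chain carbon, three bonds along the chain from an oxygen on an aromatic ring, shows that the amine group needs no ring to give a lower number than compound 3: a 3.9-fold lower number from compound 3 to compound 4 (0.59 log units; beyond the scatter). The ring-free group and the 4-phenylpiperidin-1-yl group cannot be separated at this position, with a 1.3-fold higher number from compound 1 to compound 4 (0.10 log units; within the scatter), so the ring-bearing amine of compound 1 shows no measurable difference from two open propyl chains. The (3,4-dimethoxybenzyl)amino group keeps its lead over the ring-free amine as well, with a 7.8-fold higher number from compound 2 to compound 4 (0.89 log units; beyond the scatter), so the low number of compound 2 belongs to that particular group and does not come with any amine placed here.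

As far as these compounds go, how a benzylamino group without the two methoxy groups, a morpholine or a longer chain between the oxygen and the amine would rank against these four compounds stays open. The data shown include no measured property that could account for these differences.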